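A nitro group replaces methoxy in a series of limits

The compounds below may be only part of what the source reports. "The series", "measured", "known", "first", "only" and "open" are said of these compounds alone.

Values in a functional assay on HT-29 cells (Homo sapiens) for inhibition, read by sulforhodamine B assay, with a stated time of 48 h (on this read-out lower numbers stand for stronger inhibition of growth and higher numbers for weaker inhibition of growth), each of them a limit and not a number:
- compound 1 `CC(C)(C)NCc1c(C(=O)O)nn(-c2ccc(Cl)cc2)c1-c1ccc(F)cc1`: > 623000 nM
- compound 2 `CC(C)(C)NCc1c(C(=O)O)nn(-c2ccc(Cl)cc2)c1-c1ccc(Br)cc1`: > 542000 nM
- compound 3 `COc1ccc(-c2c(CNC(C)(C)C)c(C(=O)O)nn2-c2ccc(Cl)cc2)cc1`: > 605000 nM

Compound 3 stands at the limit of > 605000 nM in this assay, at which 1 of the 3 values shown sits, which is a limit. For the measured compounds named here, compound 1 and compound 2 also give only limits, so no compound in this set has a readable number in this assay.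

Compound 4 `CC(C)(C)NCc1c(C(=O)O)nn(-c2ccc(Cl)cc2)c1-c1ccc([N+](=O)[O-])cc1` keeps the shared core and carries nitro in place of methoxy on an aromatic carbon, para to a large group, so that 4-methoxyphenyl becomes 4-nitrophenyl (nitro in place of methoxy on an aromatic carbon).

Three measured exchanges of the same kind bear on this change. Bromo in place of fluoro gives a step that the two limits leave unreadable from compound 1 to compound 2. Methoxy in place of fluoro gives a step that the two limits leave unreadable from compound 1 to compound 3. Methoxy in place of bromo gives a step that the two limits leave unreadable from compound 2 to compound 3.

None of these steps has a size, so none offers a direction to carry over to nitro. Fluoro, bromo and methoxy all ended in a limit, and compound 4 is therefore expected to end in one too. No step beyond the scatter is expected, and the estimate for the change is an at least 1.0-fold lower number from compound 3 to compound 4 (0.01 log units; that floor lies within the scatter). For compound 4 the estimated value is 585000 nM, with an expected range from 400000 nM to 800000 nM.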

Compound 4, concentration for 50% growth inhibition: > 583000 nM
Compound 4: no number, only a limit; the forecaster's own chance of this, stated with the estimate: 90%; the middle value lies beyond the limit too.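

In this assay compound 4 gives > 583000 nM, which is a limit and not a number. For the compounds shown here, compound 1, compound 2 and compound 3 also give only limits, so no step involving compound 4 can be read. The compounds shown leave open whether fluoro, bromo, methoxy and nitro differ at all in this assay.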